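Benzyl ether variation in an alpha-1B binding series

This account rests on a few compounds, and the source may have more. Where it says the series, first, only, none or still open, it means among the compounds named here.

Measured compounds:
compound 1, `COc1cccc(OC)c1OCCNCCOc1ccccc1OCc1cccc(Cl)c1`: 0.159 nM
compound 2, `COc1cccc(OC)c1OCCNCCOc1ccccc1OCc1ccccc1C`: 0.794 nM
compound 3, `COc1cccc(OC)c1OCCNCCOc1ccccc1OCc1ccc(C)cc1`: 0.251 nM

All three values come from an assay on CHO cells for displacement of a labelled ligand from Alpha-1B adrenergic receptor (Homo sapiens); a lower number here means a stronger inhibitor, a higher number a weaker inhibitor. Compound 1 gives the lowest number of the three. Compound 3 lies within the scatter of it, as a 1.6-fold higher number from compound 1 to compound 3 (0.20 log units; within the scatter) shows, so the two cannot be ordered. Compound 2 stands apart: a 5.0-fold higher number from compound 1 to compound 2 (0.70 log units; beyond the scatter) and a 3.2-fold lower number from compound 2 to compound 3 (0.50 log units; beyond the scatter) both go beyond the scatter.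

Compound 4, `COc1cccc(OC)c1OCCNCCOc1ccccc1OCc1ccc([N+](=O)[O-])cc1`, is not yet measured in this assay. Its difference from compound 1 is counted as follows: 4-nitrophenyl in place of 3-chlorophenyl on a saturated chain carbon bound to an oxygen on an aromatic ring

Both measured steps from compound 1 exchange the 3-chlorophenyl for a methyl-bearing phenyl; neither step involves a nitro group, so nothing in the set speaks directly to the change in compound 4. The name 4-nitrophenyl matches 4-methylphenyl in the numbering of its substituent, and the step to 4-methylphenyl stayed within the scatter, while the step to 2-methylphenyl went beyond it. A somewhat higher number than for compound 1 is therefore expected, near the edge of the scatter, and the expected step is a 2.5-fold higher number from compound 1 to compound 4 (0.40 log units; beyond the scatter). For compound 4 the estimate is 0.4 nM with a range of 0.1 nM to 1.6 nM.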

Compound 4, inhibition constant: 0.398 nM
Compound 4: middle estimate off by 1.0-fold (0.00 log units), on the high side; the measured number falls inside the stated range.
By their numbers in this assay, from the lowest: compounds 1, 3, 4 and 2 (each within the scatter of the next, the first and the last beyond it).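

In this assay, the step of a 2.5-fold higher number from compound 1 to compound 4 (0.40 log units; beyond the scatter) shows that the saturated chain carbon bound to an oxygen on an aromatic ring can carry 4-nitrophenyl, with its 2 hydrogen-bond acceptors, at only a modest cost relative to 3-chlorophenyl. Nitro in place of methyl on an aromatic carbon gives a 1.6-fold higher number from compound 3 to compound 4 (0.20 log units; within the scatter), so these two groups cannot be ordered here, and a 2.0-fold lower number from compound 2 to compound 4 (0.30 log units; within the scatter) means that compound 4 also cannot be ordered against 2-methylphenyl, even though compound 2 and compound 3 are separated by more than the scatter. No measurement at hand gives a reason for any of these steps.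

The change from 3-chlorophenyl to 4-nitrophenyl alters both the group and its numbering on the ring, so the compounds shown cannot separate those two contributions. Also open, from the compounds shown here alone, is whether an amine or a carboxylic acid in place of the nitro, or a plain phenyl with no substituent, would stay within the range spanned by these four compounds.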